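Benzoxaborole amides: a thiazolyl replaces cyclohexyl

The source may report more compounds than this note shows. Statements on the series, on what has been measured and on what is new or still open speak of the compounds shown alone.

Compound 1 `O=C(O)CCc1cccc2c1B(O)OC2` gives in a functional assay on SK-OV-3 cells (Homo sapiens) for antiproliferative activity, read by MTT assay, with a stated time of 72 h (a lower number here means a stronger inhibitor, a higher number a weaker inhibitor), a value that is only a limit of the assay, > 100000 nM.
Compound 2 `CCNC(=O)CCc1cccc2c1B(O)OC2` gives in this assay likewise a limit, > 100000 nM.
Compound 3 `O=C(CCc1cccc2c1B(O)OC2)NC1CCCCC1` gives in this assay again a limit, > 100000 nM.

Compound 3 thus stands at the same limit as both other compounds; none of the three gives a readable number (the limit of > 100000 nM in this assay, at which 3 of the 3 values shown sit). Compound 4 `O=C(CCc1cccc2c1B(O)OC2)Nc1nccs1` differs from compound 3 in one place: 1,3-thiazol-2-yl in place of cyclohexyl on an amide-type nitrogen. The step that bears on this change is a step that the two limits leave unreadable from compound 2 to compound 3, and the steps a step that the two limits leave unreadable from compound 1 to compound 2 and a step that the two limits leave unreadable from compound 1 to compound 3 are equally unreadable. Nothing measured therefore points to a step in either direction, and compound 4 is expected to remain at or near the limit. The expected step for compound 4 is a number no higher from compound 3 to compound 4 (the limit leaves the size open). Compound 4 is estimated at 100000 nM, in a range from 30000 nM to 300000 nM.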

Compound 4, half-maximal inhibitory concentration: > 100000 nM
Compound 4 gave a limit, no number; the forecaster's own chance of this, stated with the estimate: 75%; the middle value lies on the limit itself.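

Compound 4 gives no readable step against compound 1, compound 2 or compound 3, all four sitting at one limit: the limit of > 100000 nM in this assay, at which 4 of the 4 values shown sit.

The compounds shown leave open whether any group on the amide-type nitrogen can give a readable number in this assay.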